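The source may hold more compounds than are shown below. What is called first, only, known or untested is meant among the compounds shown, and "the series" means these compounds.

Measured so far in a functional assay on FaDu cells (Homo sapiens) for cytotoxicity, read by MTT assay, with a stated time of 72 h; a higher number here means that more compound is tolerated, a lower number that less compound is tolerated:

Compound 1 `CCC(C)n1cc(C(=O)C(=O)Nc2ccc(OC)nc2)c2ccccc21` gives 68 nM (sec-butyl on the aromatic nitrogen)
Compound 2 `COc1ccc(NC(=O)C(=O)c2cn(CC3CCCO3)c3ccccc23)cn1` gives 31 nM ((oxolan-2-yl)methyl on the aromatic nitrogen)

Compound 2 holds the lower of the two numbers, and compound 1 lies above it by more than the scatter. The next compound, compound 3 `COCC(C)(C)n1cc(C(=O)C(=O)Nc2ccc(OC)nc2)c2ccccc21`, keeps the shared core and differs from compound 2 only in the group on the aromatic nitrogen, with 1-(methoxymethyl)-1-methylethyl in place of (oxolan-2-yl)methyl (1-(methoxymethyl)-1-methylethyl in place of (oxolan-2-yl)methyl on an aromatic nitrogen). Within the data shown here, one measured step bears on this position: a 2.2-fold lower number from compound 1 to compound 2 (0.34 log units; beyond the scatter), a modest change beyond the scatter. Like the sec-butyl of compound 1, the entering group has no ring, though it keeps the oxygen of the group it replaces. Among the measured compounds shown here, no measured compound carries this group, so the evidence is thin. A modest step toward a higher number is expected, estimated as a 1.9-fold higher number from compound 2 to compound 3 (0.29 log units; within the scatter) in this assay, and a step within the scatter would not be surprising. The estimate for compound 3 is 60 nM (expected range 20 nM to 170 nM).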

Compound 3, concentration lethal to 50% of the cells in the FaDu assay: 137 nM
Compound 3: middle estimate off by 2.3-fold (0.36 log units), on the low side; low and high end bracket the measured number.
By their numbers in the FaDu assay, from the lowest: compound 2; then compounds 1 and 3 (each within the scatter of the next).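

In the FaDu assay, the oxygen of the group on the aromatic nitrogen does not by itself go with the low number that compound 2 gives, 31 nM: replacing the ring of (oxolan-2-yl)methyl with the open 1-(methoxymethyl)-1-methylethyl, which has the same heavy atoms by count and type, gives a 4.4-fold higher number from compound 2 to compound 3 (0.65 log units; beyond the scatter), while replacing sec-butyl with the same open group gives a 2.0-fold higher number from compound 1 to compound 3 (0.30 log units; within the scatter). Among the three compounds, the one with the ring, compound 2, is thus the only one that stands apart beyond the scatter from both others, and the two without a ring stay within the scatter of each other. In a physicochemical assay for solubility, in phosphate buffer, at pH 7.4 (on this read-out higher numbers stand for higher solubility and lower numbers for lower solubility), compound 2 gives 10000 nM and compound 3 gives 10000 nM; the change from the ring to the open group gives no change at the digits printed from compound 2 to compound 3 (within the scatter), and no measurement shown explains the step in cytotoxicity.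

As far as these compounds go, how a cyclopentylmethyl group, which keeps a ring without the oxygen, or an open chain ending in an amine would read in the FaDu assay remains open. From the compounds shown here alone, it also remains open whether the gap between the ring and the open group would hold on any core other than the shared one.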